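The compounds below may be only part of what the source reports. "The series", "measured", "known", "first", "only" and "open" are said of these compounds alone.

Compound 1 `CCc1ccc(-c2nc(N)c3cc(Cc4ccccc4)sc3n2)o1`: 223 nM in a functional assay on CHO-K1 cells for antagonist activity at adenosine receptor A1 (Homo sapiens), read by a beta-galactosidase reporter and cAMP accumulation, with stated times of 15 min and 6 h; a lower number here means a stronger inhibitor, a higher number a weaker inhibitor
Compound 2 `Cc1csc(-c2nc(N)c3cc(Cc4ccccc4)sc3n2)n1`: 1490 nM
Compound 3 `Nc1nc(-c2cccnc2)nc2sc(Cc3ccccc3)cc12`: 1420 nM

Compound 3 stands second highest of these three numbers. The step of a 1.0-fold lower number from compound 2 to compound 3 (0.02 log units; within the scatter) lies within the scatter, whereas the step of a 6.4-fold higher number from compound 1 to compound 3 (0.80 log units; beyond the scatter) lies beyond it. Compound 4 `Nc1nc(-c2ccncc2)nc2sc(Cc3ccccc3)cc12` differs from compound 3 by a single change: pyridin-4-yl in place of pyridin-3-yl on an aromatic carbon. Among the compounds with values here, no measured step mirrors this exact change. The nearest guide is a 1.0-fold lower number from compound 2 to compound 3 (0.02 log units; within the scatter), where one aromatic heterocycle replaced another at the same position without moving the number beyond the scatter. The expectation for compound 4 is therefore a step of a 1.3-fold higher number from compound 3 to compound 4 (0.10 log units; within the scatter), that is, none beyond the scatter. Compound 4 is estimated at 1800 nM, with a range from 700 nM to 4500 nM.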

Compound 4, inhibition constant: 812 nM
Compound 4: middle estimate off by 2.2-fold (0.35 log units), on the high side; low and high end bracket the measured number.
By their numbers in this assay, from the lowest: compound 1; then compounds 4, 3 and 2 (each within the scatter of the next).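

Moving the ring nitrogen, with pyridin-4-yl in place of pyridin-3-yl, gives a step within the scatter in this assay (a 1.7-fold lower number from compound 3 to compound 4 (0.24 log units; within the scatter)), so this position does not separate these two pyridines. Pyridin-4-yl and 4-methyl-1,3-thiazol-2-yl also stay within the scatter (a 1.8-fold lower number from compound 2 to compound 4 (0.26 log units; within the scatter)), while 5-ethylfuran-2-yl remains the one group that stands apart (a 3.6-fold higher number from compound 1 to compound 4 (0.56 log units; beyond the scatter)). Nothing measured here offers a reason for these numbers.

Still open, going by these compounds, is whether the lower number of compound 1 belongs to the furan ring or to its ethyl chain. A plain furan-2-yl group or a 5-propylfuran-2-yl group would bear on that.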